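Swapping one ether group on a shared core

The compounds below may be only part of what the source reports. "The series", "measured", "known", "first", "only" and "open" are said of these compounds alone.

- compound 1 `O=C(NCCNS(=O)(=O)c1ccc(-c2ccccc2OCc2cccc(O)c2)s1)Nc1cc(C(F)(F)F)cc(C(F)(F)F)c1` gives 17300 nM in a functional assay on HeLa cells (Homo sapiens) for inhibition, read by CCK-8 assay, with a stated time of 48 h; on this read-out lower numbers stand for stronger inhibition and higher numbers for weaker inhibition
- compound 2 `O=C(NCCNS(=O)(=O)c1ccc(-c2ccccc2O[C@H]2CC[C@@H](O)CC2)s1)Nc1cc(C(F)(F)F)cc(C(F)(F)F)c1` gives 14100 nM in this assay

Compound 2 holds the lower of the two numbers, but its value and that of compound 1 lie within the scatter of each other, so neither can be ranked ahead. Compound 3 `Nc1ccc(Oc2ccccc2-c2ccc(S(=O)(=O)NCCNC(=O)Nc3cc(C(F)(F)F)cc(C(F)(F)F)c3)s2)cc1` carries 4-aminophenyl in place of 4-hydroxycyclohexyl on an oxygen on an aromatic ring, with 4-aminophenyl in place of 4-hydroxycyclohexyl on an oxygen on an aromatic ring as the full difference. Within the data shown here, the one measured step at that place is a 1.2-fold lower number from compound 1 to compound 2 (0.09 log units; within the scatter) and it stays within the scatter. Among the measured compounds shown here, no measured compound carries 4-aminophenyl, so this group is untested. The expected step in this assay is a 1.2-fold lower number from compound 2 to compound 3 (0.07 log units; within the scatter) and thus none beyond the scatter. Compound 3 is estimated at 12000 nM with 5000 nM to 28000 nM as the expected range.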

Compound 3, half-maximal inhibitory concentration: > 20000 nM
Compound 3 gave a limit, no number (the forecaster's own chance of this, stated with the estimate: 10%); at least 1.6-fold (0.22 log units) between middle value and limit.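

Compound 3 gives a limit of the assay and not a number: the limit of > 20000 nM in this assay, at which 1 of the 3 values shown sits. The steps therefore have only floors, an at least 1.4-fold higher number from compound 2 to compound 3 (0.15 log units; that floor lies within the scatter) and an at least 1.1-fold higher number from compound 1 to compound 3 (0.06 log units; that floor lies within the scatter), and both floors lie within the scatter, so compound 3 cannot be ranked against either earlier compound in this assay. Among these compounds, what compound 3 adds is a first look at an aromatic ring set directly on the ether oxygen, and with 4-aminophenyl at this place no measured potency appears at all.

Going by these compounds, the true size of both steps remains open, as does any value for compound 3 beyond its limit. The change to 4-aminophenyl alters the ring and its end group together, and an aminocyclohexyl or hydroxyphenyl group on the same oxygen would be needed to tell those two changes apart.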